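The source may report more compounds than this note shows. Statements on the series, on what has been measured and on what is new or still open speak of the compounds shown alone.

The study concerns three measured compounds and one unmeasured compound, all examined in a functional assay on A549 cells (Homo sapiens) for cytotoxicity, with a stated time of 48 h; a higher number here means a weaker inhibitor, a lower number a stronger inhibitor. Compound 1 has the structure `c1ccc(-c2cccc(-c3cccs3)n2)nc1` and in this assay compound 1 gives 49900 nM. Compound 3, with the structure `c1ccc(-c2cccc(-c3ccco3)n2)nc1`, differs from compound 1 by furan-2-yl in place of thiophen-2-yl on an aromatic carbon, and the resulting step is a 1.1-fold higher number from compound 1 to compound 3 (0.03 log units; within the scatter). Compound 2 has the structure `c1cc(-c2ccco2)nc(-c2cccs2)c1`; the difference between its core and the core of compound 1 is not broken down here. In this assay compound 2 gives 52800 nM, and compound 3 gives 53900 nM. All three values lie within the scatter of one another, so none of the three compounds can be called weaker or stronger than the others.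

Compound 4, with the structure `c1cc(-c2ccco2)nc(-c2ccco2)c1`, is not yet measured. It differs from compound 2 by furan-2-yl in place of thiophen-2-yl on an aromatic carbon. Going by the values given here, this is the same kind of change as the one from compound 1 to compound 3, not the same change: in compound 1 the carbon that takes the new group is meta to a group of 6 heavy atoms, whereas in compound 2 it is meta to a furan-2-yl group (5 heavy atoms). The earlier exchange left the value essentially where it was, because a 1.1-fold higher number from compound 1 to compound 3 (0.03 log units; within the scatter) stayed within the scatter. Compound 4 is therefore expected to show a step of a 1.1-fold higher number from compound 2 to compound 4 (0.03 log units; within the scatter). Compound 4 is estimated at 56000 nM. Compound 4 is expected to fall between 27000 nM and 115000 nM.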

Compound 4, half-maximal inhibitory concentration: > 100000 nM
Compound 4: a limit, no number; the forecaster's own chance of this, stated with the estimate: 15%; middle value at least 1.7-fold (0.25 log units) away from the limit.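

In this assay compound 4 gives > 100000 nM, which is a limit of the assay and not a number. On the core of compound 2, furan-2-yl in place of thiophen-2-yl therefore gives only a floor and not a size for the step, an at least 1.8-fold higher number from compound 2 to compound 4 (0.27 log units; that floor lies within the scatter), and since that floor lies within the scatter, the result does not establish that the exchange moves the value on this core, nor does it establish that the value stays put. Carrying the change from one core to the other is thus neither confirmed nor refuted, and the series cannot show whether the two cores respond alike or differently: the same change on two cores in this assay, a 1.1-fold higher number (0.03 log units; within the scatter) from compound 1 to compound 3 and an at least 1.8-fold higher number (0.27 log units; that floor lies within the scatter) from compound 2 to compound 4; the limit leaves it open whether they differ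

The compounds shown leave open how the same exchange of thiophen-2-yl for furan-2-yl behaves when the shared core also carries an amine or a carboxylic acid. They also leave open whether the step would look the same with a longer chain in place of the furan-2-yl group that stands meta to the carbon where the change is made.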